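A few compounds are considered here, and "the series" means these few. Any claim that something is new, unique, unknown or untested is made for them only; others in the source may bear on it.

Working notes on the series. Compound 1 `Cc1ccccc1-n1nc(C)c2c1NC(=O)[C@H](C)S[C@@H]2c1ccc(/C=C/c2ccccc2)cc1` carries a 2-phenylethenyl group on the aromatic carbon that, in the other members, bears a phenoxy or biaryl group. In an assay on isolated protein for agonist activity at Bile acid receptor (Homo sapiens), read by AlphaScreen, with a stated time of 30 min (on this read-out higher numbers stand for an effect only at larger amounts of compound and lower numbers for an effect already at smaller amounts), compound 1 gives "not active" (no number reported), so no number can be placed for it among the measured values; it stands apart from compound 2 `COc1ccccc1-n1nc(C)c2c1NC(=O)[C@H](C)S[C@@H]2c1ccc(Oc2ccccc2)cc1`, which in this assay gives 3300 nM, and from compound 3 `Cc1cccc(-n2nc(C)c3c2NC(=O)[C@H](C)S[C@@H]3c2ccc(Oc3ccccc3)cc2)c1`, which gives 2400 nM. Within the data shown here, the one step recorded, a 1.4-fold lower number from compound 2 to compound 3 (0.14 log units; within the scatter), concerns the aryl group on the aromatic nitrogen and not the position changed here, so it offers no direct guide. Compound 4 `Cc1ccccc1-n1nc(C)c2c1NC(=O)[C@H](C)S[C@@H]2c1ccc(-c2ccsc2)cc1` differs from compound 1 by thiophen-3-yl in place of 2-phenylethenyl on an aromatic carbon. Among the measured compounds shown here, with compound 1 giving no number, no measured step bears on this change; the only anchor is that compounds 2 and 3, with a different group at the same carbon, both return numbers in the low micromolar range. For compound 4 the expectation is therefore a value of roughly 5000 nM, estimated to lie between 1500 nM and 20000 nM, with a real chance that, like compound 1, no number is reported.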

Compound 4, half-maximal effective concentration: 1400 nM
Compound 4: middle estimate off by 3.6-fold (0.55 log units), on the high side, outside the stated range (below it).
By their numbers in this assay, from the lowest: compounds 4, 3 and 2 (each within the scatter of the next, the first and the last beyond it).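

Among these compounds, compound 1 gives "not active" (no number reported) and compound 4 gives 1400 nM with no step readable between them. The compounds shown leave open how thiophen-3-yl compares with phenoxy at this carbon on an otherwise identical core. No supporting data bear on this result.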